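Swapping the isoquinolinyl group of compound 1 for a methylthiophenyl

A few compounds are considered here, and "the series" means these few. Any claim that something is new, unique, unknown or untested is made for them only; others in the source may bear on it.

Measured compounds:
compound 1, `O=C(NO)c1ccc(NCc2nc(-c3cccc4cnccc34)nn2-c2ccccc2)cc1`: 40.2%
compound 2, `Cc1ccc(-n2nc(-c3ccccc3)nc2CNc2ccc(C(=O)NO)cc2)cc1`: 60.7%
compound 3, `O=C(NO)c1ccc(NCc2nc(-c3ccccc3)nn2-c2cccc(Cl)c2)cc1`: 62.3%

In an assay on Sf9 cells for inhibition of protein deacetylase HDAC6 (Homo sapiens), read by fluorescence, with a stated time of 40 min, tested at 100 nM (a higher number here means more inhibition at the concentration tested (going by the name of the read-out), a lower number less inhibition), compound 1 gives the lowest of the three numbers, standing beyond the scatter below compounds 2 and 3, which differ from it at the aromatic carbon between the two ring nitrogens and from each other only by a number 1.6 percentage points higher from compound 2 to compound 3 (within the scatter). Compound 4, `Cc1ccsc1-c1nc(CNc2ccc(C(=O)NO)cc2)n(-c2ccccc2)n1`, differs from compound 1 by 3-methylthiophen-2-yl in place of isoquinolin-5-yl on an aromatic carbon. Among the measured compounds shown here, no measured step bears on this change; the one step known, from compound 2 to compound 3, concerns a different place and lies within the scatter. Compounds 2 and 3, which carry a phenyl at that carbon, stand higher than compound 1, but nothing shows how a thiophenyl behaves there. Compound 4 is therefore expected to gain moderately, by a number 11.8 percentage points higher from compound 1 to compound 4 (beyond the scatter), to an estimated 52% (range 35% to 70%).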

Compound 4, a percentage reported as inhibition, at one concentration (the size of the read-out at that concentration, not a potency): 72.1%
Estimate against measurement, compound 4: 20.1 percentage points below; the measured number lies above the stated range.
By their numbers in this assay, from the lowest: compound 1; then compounds 2, 3 and 4 (each within the scatter of the next, the first and the last beyond it).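

In this assay, 3-methylthiophen-2-yl in place of isoquinolin-5-yl gives a number 31.9 percentage points higher from compound 1 to compound 4 (beyond the scatter), the first step measured at this aromatic carbon between two ring nitrogen atoms. It shows that the read-out responds strongly to the group at this position, and that a five-membered aromatic ring of 6 heavy atoms can replace the larger 10-atom group with a large gain. The data shown offer no evidence that explains this gain. Still open, going by these compounds, is whether the gain belongs to the thiophene ring or to its methyl, which an unsubstituted thiophen-2-yl would separate. Also open, on these data alone, is whether a furan-2-yl would behave alike.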